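The source may hold more compounds than are shown below. What is called first, only, known or untested is meant among the compounds shown, and "the series" means these compounds.

Series notes. Compound 1 `CCN(Cc1ccccc1)C(=O)C1CCN(S(=O)(=O)c2ccc3[nH]ncc3c2)CC1` is the reference point of the set. In a functional assay on CHO cells for positive allosteric modulation of muscarinic acetylcholine receptor M5 (Homo sapiens), read by calcium flux (a lower number here means a smaller maximal response, a higher number a larger maximal response), compound 1 gives 86%. Among the measured compounds shown here, compound 2 `CCN(Cc1ccccc1)C(=O)C1CCN(S(=O)(=O)c2cccc3nsnc23)CC1` belongs to the same series but carries no result: in this assay compound 2 shows "not determined" (no result reported), so compound 1 holds the only number at hand, and there is no measured step from which to read the weight of a structural change.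

Compound 3 `CCN(C(=O)C1CCN(S(=O)(=O)c2ccc3[nH]ncc3c2)CC1)[C@H](C)c1ccccc1` is not yet measured. It differs from compound 1 in a single place: methyl in place of hydrogen on a saturated chain carbon bound to an amide-type nitrogen and an aromatic carbon.

For the measured compounds named here, with no step between measured compounds to lean on, the expectation for this change rests on compound 1 alone, with its 86% as the anchor. The step from compound 1 to compound 3 in this assay is expected to be small, if anything a slight fall, and most likely not beyond the scatter: a number 6 percentage points lower from compound 1 to compound 3 (within the scatter). Compound 3 is therefore estimated at 80%, within a range from 55% to 100%.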

Compound 3, largest response reached (reported as percent of maximum), in percent of the reference or control that the assay uses: 86%
Compound 3: middle estimate off by 6 percentage points, on the low side; the measured number falls inside the stated range.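

In this assay the series now has one measured step, and it reads no change at the digits printed from compound 1 to compound 3 (within the scatter) for methyl in place of hydrogen on a saturated chain carbon bound to an amide-type nitrogen and an aromatic carbon. Among the compounds shown here, this position therefore accepts the change from benzyl to 1-phenylethyl, in the single configuration of compound 3, with no loss of maximal response beyond the scatter, something compound 1 alone could not show. No measurement at hand bears on the reason for this result.

The compounds shown leave open whether the opposite configuration of 1-phenylethyl would give the same maximal response. They also leave open how far this carbon tolerates anything larger than methyl, such as an ethyl group, a hydroxymethyl group or an aminomethyl group.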